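The compounds below may be only part of what the source reports. "The series", "measured", "known", "first", "only" and "open" are said of these compounds alone.

Measured so far:
Compound 1 `N#Cc1cccc(C(=O)NC(=S)N2CCc3c(OCCCCCOc4ccc(Cl)cc4)cccc32)c1`: 9750 nM
Compound 2 `CN(C)c1ccc(C(=O)NC(=S)N2CCc3c(OCCCCCOc4ccc(Cl)cc4)cccc32)cc1`: > 50000 nM
Compound 3 `O=C(NC(=S)N1CCc2c(OCCCCCOc3ccc(Cl)cc3)cccc21)C1CCCCC1`: > 50000 nM

Within the data shown here, in an ADME assay on Huh-7 cells (Homo sapiens) for cytotoxicity (a lower number here means that less compound is tolerated, a higher number that more compound is tolerated), compound 1 gives 9750 nM, the only plain number among the three measured compounds. The value of compound 2 is a limit of the assay, not a number. The value of compound 3 is likewise a limit. Both sit at the limit of > 50000 nM in this assay, at which 2 of the 3 values shown sit.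

Compound 4 `O=C(NC(=S)N1CCc2c(OCCCCCOc3ccc(Cl)cc3)cccc21)c1ccc2ccccc2c1` differs from compound 1 by naphthalen-2-yl in place of 3-cyanophenyl on a carbonyl carbon. Two measured steps start from compound 1 and replace the same group: an at least 5.1-fold higher number from compound 1 to compound 2 (0.70 log units; beyond the scatter) and an at least 5.1-fold higher number from compound 1 to compound 3 (0.70 log units; beyond the scatter). Both steps raised the number beyond the scatter, and each ended at a limit. A rise is therefore expected for compound 4 as well, estimated as a 4.1-fold higher number from compound 1 to compound 4 (0.61 log units; beyond the scatter). Compound 4 is expected near 40000 nM, within 15000 nM to 50000 nM, quite possibly again only a limit.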

Compound 4, half-maximal cytotoxic concentration: > 50000 nM
Compound 4: a limit, no number (the forecaster's own chance of this, stated with the estimate: 55%); middle value at least 1.2-fold (0.09 log units) from the limit.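

In this assay, naphthalen-2-yl, with two six-membered aromatic rings of carbon only, gives an at least 5.1-fold higher number from compound 1 to compound 4 (0.70 log units; beyond the scatter). All three replacements of 3-cyanophenyl on this carbonyl carbon now raise the number beyond the scatter, whether the new group is aromatic or not, and none goes against this. The steps among compound 2, compound 3 and compound 4 cannot be read: the limit of > 50000 nM in this assay, at which 3 of the 4 values shown sit.

Still open, from the compounds shown here alone, is whether the nitrile of compound 1 accounts for its lower number or the whole 3-cyanophenyl group does. An unsubstituted phenyl group on the same carbonyl carbon would help separate the two.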